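This account rests on a few compounds, and the source may have more. Where it says the series, first, only, none or still open, it means among the compounds named here.

Compound 1 `COc1cc(Cl)cc(-c2nn(-c3cccc(NC(=O)c4ccc(Cl)c(Cl)c4)c3)cc2-c2ccncc2)c1` — compound 1 gives 80.8% in a functional assay on MDA-MB-435 cells (Homo sapiens) for inhibition, read by sulforhodamine B assay, with a stated time of 48 h, tested at 10 uM; on this read-out higher numbers stand for a weaker effect at the one concentration tested and lower numbers for a stronger effect.
Compound 2 `O=C(Nc1cccc(-n2cc(-c3ccncc3)c(-c3cc(O)cc(Cl)c3)n2)c1)Nc1ccc(Cl)c(Cl)c1` — compound 2 gives -33.3% in this assay.
Compound 3 `COc1cc(Cl)cc(-c2nn(-c3cccc(NC(=O)Nc4cccc(C(F)(F)F)c4)c3)cc2-c2ccncc2)c1` — compound 3 gives -20.9% in this assay.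

Among these three, compound 1 stands highest in this assay, that is, it shows the weakest effect; its nearest neighbour on the numbers is compound 3, and compound 2 lies furthest from it. Compound 4 `COc1cc(Cl)cc(-c2nn(-c3cccc(NC(=O)c4cccc(C(F)(F)F)c4)c3)cc2-c2ccncc2)c1` has not yet been measured. It differs from compound 1 in one place: 3-(trifluoromethyl)phenyl in place of 3,4-dichlorophenyl on a carbonyl carbon

Among the measured compounds shown here, only one measured step bears on this change, and it does not isolate it. From compound 1 to compound 3, the 3,4-dichlorophenyl on the carbonyl carbon is replaced by (3-(trifluoromethyl)phenyl)amino, and this assay moves a number 101.7 percentage points lower from compound 1 to compound 3 (beyond the scatter). Compound 4 carries the same 3-(trifluoromethyl)phenyl but keeps the carbonyl carbon bonded to it directly, so how much of that step belongs to the aryl exchange alone cannot be read off; compound 2, carrying 3,4-dichlorophenyl, gives -33.3% and shows that the dichloro group itself does not fix a weak effect. On this basis a drop beyond the scatter, smaller than the measured step, is expected: a number 45.8 percentage points lower from compound 1 to compound 4 (beyond the scatter). Compound 4 is therefore estimated at 35%, with a range from -25% to 85%.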

Compound 4, a percentage reported as activity, at one concentration (the size of the read-out at that concentration, not a potency): 65.6%
For compound 4 the middle estimate is 30.6 percentage points below the measured one; the measured number falls inside the stated range.
By their numbers in this assay, from the lowest: compound 2; then compound 3; then compound 4; then compound 1.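

The aryl exchange on the carbonyl carbon, taken alone, proves small in this assay: with the amide-type nitrogen kept, it gives a number 15.2 percentage points lower from compound 1 to compound 4 (beyond the scatter), a modest step. With 3-(trifluoromethyl)phenyl held constant, taking away the amino group on the carbonyl carbon gives a number 86.5 percentage points higher from compound 3 to compound 4 (beyond the scatter), so the large step seen earlier from compound 1 to compound 3 goes mostly with the amino group and only to a small extent with the change of aryl group. No measurement is available that explains this difference.

It remains open whether the amino group would have an effect of the same size with 3,4-dichlorophenyl on the carbonyl carbon in the core of compound 1, since the only compound shown with that pairing, compound 2, differs from compound 1 in a second place as well. Also open, from the compounds shown here alone, is how a methylene group, an oxygen atom or a methylamino group would fare on the carbonyl carbon in place of the amino group of compound 3.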